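Extending the Methoxy Group: Compound 4 in Prospect

The source may hold more compounds than are shown below. What is called first, only, known or untested is meant among the compounds shown, and "the series" means these compounds.

Compound 3 `COc1ccc(/C=N/NC(=O)c2cnccn2)cc1` stands lowest of the three compounds measured in an ADME assay on J774 cells (Mus musculus) for cytotoxicity, read by MTT assay, with a stated time of 48 h, tested at 50 ug/mL (on this read-out lower numbers stand for a stronger effect and higher numbers for a weaker effect at the one concentration tested), where compound 3 gives 74%. Compound 1 `O=C(N/N=C/c1ccccc1)c1cnccn1` gives 100% and compound 2 `O=C(N/N=C/c1ccc(Br)cc1)c1cnccn1` gives 100%; the steps of a number 26 percentage points lower from compound 1 to compound 3 (beyond the scatter) and a number 26 percentage points lower from compound 2 to compound 3 (beyond the scatter) set compound 3 apart from both, while no change at the digits printed from compound 1 to compound 2 (within the scatter) shows no movement. Compound 4 `CCOc1ccc(/C=N/NC(=O)c2cnccn2)cc1` differs from compound 3 by methyl in place of hydrogen on a saturated chain carbon bound to an oxygen on an aromatic ring. For the measured compounds named here, no measured step lengthens this chain, so the two steps ending at compound 3 bear on it only indirectly, and nothing among them argues for a further drop or a return upward. For compound 4 a step of a number 4 percentage points lower from compound 3 to compound 4 (within the scatter) is expected, within the scatter. Compound 4 is therefore estimated at 70%, with a range from 45% to 95%.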

Compound 4, a percentage reported as activity, at one concentration (the size of the read-out at that concentration, not a potency): 100%
Compound 4: middle estimate off by 30 percentage points, on the low side; the whole stated range lies below it.
By their numbers in this assay, from the lowest: compound 3; then compounds 1, 2 and 4 (each within the scatter of the next).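

In this assay the methoxy group does not tolerate even one added methyl without losing its effect, with a number 26 percentage points higher from compound 3 to compound 4 (beyond the scatter) on this small extension. With no change at the digits printed from compound 1 to compound 4 (within the scatter) and no change at the digits printed from compound 2 to compound 4 (within the scatter) as well, the ethoxy group cannot be told apart from hydrogen or bromo. Among the four compounds the lower number therefore belongs to methoxy alone and does not carry over to ethoxy, and nothing available explains this reversal.

From the compounds shown here alone, whether a hydroxy group, an amine or a longer chain such as propoxy would read like methoxy or like ethoxy remains open.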